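The compounds below may be only part of what the source reports. "The series", "measured", "known", "first", "only" and "open" are said of these compounds alone.

Compound 2 `CC(C)c1c(C(=O)N2CCC[C@H](c3ccccc3)C2)nn(-c2ccc(F)cc2)c1OC[C@@H](O)C[C@@H](O)CC(=O)O` is the stronger of the two measured compounds in an assay on microsomes from liver for inhibition of 3-hydroxy-3-methylglutaryl-coenzyme A reductase (Rattus norvegicus); a lower number here means a stronger inhibitor, a higher number a weaker inhibitor: compound 2 gives 4.8 nM, whereas compound 1 `Cc1ccc(CNC(=O)c2nn(-c3ccc(F)cc3)c(OC[C@@H](O)C[C@@H](O)CC(=O)O)c2C(C)C)cc1` gives 15 nM. Within the data shown here, the only measured step in this pair is a 3.1-fold lower number from compound 1 to compound 2 (0.49 log units; beyond the scatter), which replaced (4-methylbenzyl)amino on the carbonyl carbon with 3-phenylpiperidin-1-yl.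

Compound 3 `Cc1ccccc1CNC(=O)c1nn(-c2ccc(F)cc2)c(OC[C@@H](O)C[C@@H](O)CC(=O)O)c1C(C)C` returns to a benzylic amide: the change from compound 2 is (2-methylbenzyl)amino in place of 3-phenylpiperidin-1-yl on a carbonyl carbon. This is essentially the reverse of the measured step, except that the group entering is (2-methylbenzyl)amino rather than the (4-methylbenzyl)amino of compound 1. Among the measured compounds shown here, no measured pair shows what exchanging one methylbenzyl amide for the other does in this assay, so that part of the change is uncertain.

Since compound 1 gave 15 nM and the step of a 3.1-fold lower number from compound 1 to compound 2 (0.49 log units; beyond the scatter) was modest, the reverse is expected to be of similar size in the opposite direction, so compound 3 is expected to sit near compound 1. Accordingly compound 3 is estimated to give 15 nM in this assay, within a range of 6 nM to 40 nM, meaning an expected step of a 3.1-fold higher number from compound 2 to compound 3 (0.49 log units; beyond the scatter).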

Compound 3, half-maximal inhibitory concentration: 17 nM
Compound 3: middle estimate off by 1.1-fold (0.05 log units), on the low side; measured number inside the range.
By their numbers in this assay, from the lowest: compound 2; then compounds 1 and 3 (each within the scatter of the next).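

In this assay, the new result shows that the place of the methyl group on the benzylic amide makes no measurable difference here: with 2-methylphenyl in place of 4-methylphenyl on a saturated chain carbon bound to an amide-type nitrogen, the record is a 1.1-fold higher number from compound 1 to compound 3 (0.05 log units; within the scatter) and the two amides cannot be told apart. The gap to the 3-phenylpiperidin-1-yl amide is therefore seen from both benzylic amides, as a 3.5-fold higher number from compound 2 to compound 3 (0.55 log units; beyond the scatter) is of similar size to the earlier 3.1-fold lower number from compound 1 to compound 2 (0.49 log units; beyond the scatter) in the opposite direction, so across these three compounds the division lies between the two kinds of amide and not between the two methylphenyl groups. Nothing available offers an explanation for this division.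

The compounds shown leave open whether the gap follows the piperidine ring, the second phenyl ring or the amide hydrogen, which only compound 3 and compound 1 carry; a benzyl(methyl)amino group would keep the benzyl and lose that hydrogen. They also leave open whether the insensitivity extends beyond methyl, for example to a chlorobenzylamino or methoxybenzylamino group, or to unsubstituted benzylamino.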